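Acetamidomethyl added to the bare core of compound 3

A few compounds are considered here, and "the series" means these few. Any claim that something is new, unique, unknown or untested is made for them only; others in the source may bear on it.

Compound 3 `CC1(C)c2cc(Cl)ccc2C(=O)N1c1cccnc1` is the unsubstituted core of this set. In an assay on cells for inhibition of cytochrome P450 11B2, mitochondrial (Homo sapiens), read by HTRF (on this read-out higher numbers stand for weaker inhibition and lower numbers for stronger inhibition), compound 3 gives 108 nM, the highest of the three numbers at hand. Compound 1 `C[C@@H](NS(C)(=O)=O)c1cncc(N2C(=O)c3ccc(Cl)cc3C2(C)C)c1` carries a group on that aromatic carbon and in this assay compound 1 gives 8 nM. Compound 2 `CC(=O)N1CCC(c2cncc(N3C(=O)c4ccc(Cl)cc4C3(C)C)c2)CC1` carries a different group there and in this assay compound 2 gives 5 nM. Swapping one group for the other, a 1.6-fold lower number from compound 1 to compound 2 (0.20 log units; within the scatter), so the two occupied analogues stand together. Removing either group to reach the bare core is a large step: a 14-fold higher number from compound 1 to compound 3 (1.13 log units; beyond the scatter) and a 22-fold higher number from compound 2 to compound 3 (1.33 log units; beyond the scatter).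

Compound 4 `CC(=O)NCc1cncc(N2C(=O)c3ccc(Cl)cc3C2(C)C)c1` differs from compound 3 by acetamidomethyl in place of hydrogen on an aromatic carbon. Both measured steps bear on this change, since each fills the same aromatic carbon, and both were large and in the same direction. Among the measured compounds shown here, the acetamidomethyl group itself has no precedent in the set, so the range stays wide. Compound 4 is therefore expected to give a clearly lower number, a 9.0-fold lower number from compound 3 to compound 4 (0.95 log units; beyond the scatter), with an estimate of 12 nM and a range from 4 nM to 40 nM.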

Compound 4, half-maximal inhibitory concentration: 59 nM
The estimate for compound 4 lay 4.9-fold (0.69 log units) below the measured number; measured number outside the range, above it.
By their numbers in this assay, from the lowest: compounds 2 and 1 (each within the scatter of the next); then compounds 4 and 3 (each within the scatter of the next).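

In this assay the step for acetamidomethyl is a 1.8-fold lower number from compound 3 to compound 4 (0.26 log units; within the scatter) and so leaves compound 4 with the bare core: filling this aromatic carbon does not by itself give the low numbers of the two earlier analogues. Both a 12-fold higher number from compound 2 to compound 4 (1.07 log units; beyond the scatter) and a 7.4-fold higher number from compound 1 to compound 4 (0.87 log units; beyond the scatter) lie beyond the scatter, so the identity of the group on this carbon counts, not occupancy alone. Nothing measured here accounts for the difference between these groups.

The compounds shown do not separate the acetamide from the length of its link to the ring; methanesulfonamidomethyl or a longer chain such as 2-acetamidoethyl would bear on that. Going by these compounds, whether a free amine such as aminomethyl on this carbon would stand with compound 3 or with compound 1 also stays open.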